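A few compounds are considered here, and "the series" means these few. Any claim that something is new, unique, unknown or untested is made for them only; others in the source may bear on it.

Of the compounds shown here, three with a shared core have numbers so far in a functional assay on HL-60 cells (Homo sapiens) for inhibition, read by CCK-8 assay, with a stated time of 48 h, tested at 20 uM; a higher number here means more inhibition of growth at the concentration tested, a lower number less inhibition of growth: compound 1 (`Cc1ccc(S(=O)(=O)Oc2cccc(/C=C(\C#N)C(=O)Nc3nnc(C)s3)c2)cc1`) gives 71%, compound 2 (`Cc1ccc(S(=O)(=O)Oc2cccc(/C=C(\C#N)C(=O)Nc3nnc(-c4ccccc4)s3)c2)cc1`) gives 63%, and compound 3 (`Cc1ccc(S(=O)(=O)Oc2cccc(/C=C(\C#N)C(=O)Nc3nnc(-c4cccs4)s3)c2)cc1`) gives 62%. Compound 3 stands within the scatter of both others.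

Compound 4 (`N#C/C(=C\c1cccc(NS(=O)(=O)c2ccc(F)cc2)c1)C(=O)Nc1nnc(-c2cccs2)s1`) keeps the thiophen-2-yl of compound 3 and differs at another place, on an aromatic carbon meta to a large group: ((4-fluorophenyl)sulfonyl)amino in place of ((4-methylphenyl)sulfonyl)oxy on an aromatic carbon.

The measured steps all lie elsewhere: a number 8 percentage points lower from compound 1 to compound 2 (within the scatter), a number 9 percentage points lower from compound 1 to compound 3 (within the scatter) and a number 1 percentage points lower from compound 2 to compound 3 (within the scatter), each within the scatter. All three measured compounds carry the ((4-methylphenyl)sulfonyl)oxy group, so the series gives no measured size or direction for this replacement. The expectation therefore rests on compound 3 at 62%, with no shift beyond the scatter assumed and a wide margin kept for the untested change.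

The estimated change is a number 4 percentage points lower from compound 3 to compound 4 (within the scatter), expected to stay within the scatter. For compound 4, the estimated value in this assay is 58%, with an expected range of 36% to 80%.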

Compound 4, percent growth inhibition at one concentration: "not active" (no number reported)
No number was reported for compound 4; no gap can be computed for the estimate.
By their numbers in this assay, from the lowest: compounds 3, 2 and 1 (each within the scatter of the next).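

Within the data shown here, compound 4 is reported in this assay as not active, without a number, so no step from compound 3 to compound 4 can be read. No evidence on hand bears on this result. The compounds shown leave open whether the sulfonyl amino link or the fluorine goes with this result, since the two differ together.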